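Replacing Cyclohexyl with Phenyl: Expected Gain in Inhibition

The source may hold more compounds than are shown below. What is called first, only, known or untested is meant among the compounds shown, and "the series" means these compounds.

Measured in an assay for inhibition of histone-lysine N-methyltransferase, H3 lysine-79 specific (Homo sapiens), read by scintillation counting, with stated times of 15 min and 60 min, tested at 25 uM, in the presence of a further agent that is not named here; a higher number here means a stronger effect of the compound at the concentration tested, a lower number a weaker effect:
compound 1 `C(=C/c1nn2c(-c3ccncc3)nnc2s1)\c1ccco1` gives 54%
compound 2 `Cc1cccc(-c2nnc3sc(/C=C/c4ccco4)nn23)c1` gives 66.6%
compound 3 `C(=C/c1nn2c(C3CCCCC3)nnc2s1)\c1ccco1` gives 40.2%

Compound 3 stands lowest of the three, below both others beyond the scatter. Compound 4 `C(=C/c1nn2c(-c3ccccc3)nnc2s1)\c1ccco1` differs from it in one place: phenyl in place of cyclohexyl on an aromatic carbon. Within the data shown here, two measured steps bear on this change. Each time cyclohexyl entered in place of an aromatic ring, inhibition fell: a number 13.8 percentage points lower from compound 1 to compound 3 (beyond the scatter) and a number 26.4 percentage points lower from compound 2 to compound 3 (beyond the scatter). Here the move runs the other way, with an aromatic ring entering. Phenyl is neither the pyridin-4-yl of compound 1 nor the 3-methylphenyl of compound 2; a rise of a size between those two steps is expected. For compound 4 the expected step is a number 19.8 percentage points higher from compound 3 to compound 4 (beyond the scatter). The estimate for compound 4 is 60%, ranging from 45% to 75%.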

Compound 4, a percentage reported as inhibition, at one concentration (the size of the read-out at that concentration, not a potency): 79.4%
Beside the measured number, compound 4's estimate is 19.4 percentage points below it; measured number above the stated range.
By their numbers in this assay, from the lowest: compound 3; then compound 1; then compound 2; then compound 4.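

Among these compounds, exchanging cyclohexyl for phenyl, with the heavy atom count unchanged, gives a number 39.2 percentage points higher from compound 3 to compound 4 (beyond the scatter), the largest step at this position so far, so here an aromatic ring and a non-aromatic ring are far from interchangeable. The unsubstituted phenyl also beats both other aromatic rings: dropping the methyl gives a number 12.8 percentage points higher from compound 2 to compound 4 (beyond the scatter), and phenyl in place of pyridin-4-yl gives a number 25.4 percentage points higher from compound 1 to compound 4 (beyond the scatter). Nothing measured here explains these differences. From the compounds shown here alone, whether a phenyl ring carrying an amine or a carboxylic acid would keep this level of inhibition remains open. So does the effect of a longer chain at this position.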